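Halogen swap at the para position in the shared core

The source may hold more compounds than are shown below. What is called first, only, known or untested is meant among the compounds shown, and "the series" means these compounds.

Measured compounds:
Compound 1 `N#Cc1ccc(-c2csc(N/N=C/c3ccc(N4CCCC4)cc3)n2)cc1`, 66300 nM
Compound 2 `Clc1ccc(-c2csc(N/N=C/c3ccc(N4CCCC4)cc3)n2)cc1`, 45200 nM

Both compounds were tested in an assay on isolated protein for inhibition of Amine oxidase [flavin-containing] A (Homo sapiens), read by fluorescence and Amplex Red, with a stated time of 30 min; on this read-out lower numbers stand for stronger inhibition and higher numbers for weaker inhibition. Among the compounds with values here, compound 2 has the lower of the two numbers; compound 1 sits close by, and the single measured step, a 1.5-fold lower number from compound 1 to compound 2 (0.17 log units; within the scatter), is within the scatter, so the two cannot be told apart on these data.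

Compound 3 `Fc1ccc(-c2csc(N/N=C/c3ccc(N4CCCC4)cc3)n2)cc1` is not yet measured. It differs from compound 2 by one change: fluoro in place of chloro on an aromatic carbon. Within the data shown here, the only step available, from compound 1 to compound 2, changed a group at this same place, and its size, a 1.5-fold lower number from compound 1 to compound 2 (0.17 log units; within the scatter), was too small to count as a real change. A swap of one halogen for another at the same place is therefore expected to leave the number within the scatter, with no direction that can be predicted from what is known. For compound 3 the expected step is a 1.2-fold higher number from compound 2 to compound 3 (0.09 log units; within the scatter). The estimated value for compound 3 in this assay is 55000 nM, with a likely range from 25000 nM to 120000 nM.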

Compound 3, half-maximal inhibitory concentration: 13100 nM
Beside the measured number, compound 3's estimate is 4.2-fold (0.62 log units) above it; the whole stated range lies above it.
By their numbers in this assay, from the lowest: compound 3; then compounds 2 and 1 (each within the scatter of the next).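

In this assay the group at this place turns out to matter, which the earlier pair could not show, since a 1.5-fold lower number from compound 1 to compound 2 (0.17 log units; within the scatter) stayed within the scatter. Fluoro in place of chloro gives a 3.5-fold lower number from compound 2 to compound 3 (0.54 log units; beyond the scatter) and fluoro in place of cyano gives a 5.1-fold lower number from compound 1 to compound 3 (0.70 log units; beyond the scatter), both beyond the scatter, so compound 3 is the strongest of the three and fluoro stands apart from the two other groups, which cannot be told apart from each other; exchanging one halogen atom for another, with no ring, hydrogen-bond donor, hydrogen-bond acceptor or net charge entering or leaving, is enough to produce a real step. Nothing available explains why fluoro differs from chloro and cyano here.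

Only three groups at this one place are shown, so it stays open whether the number would keep falling, hold or rise with a plain hydrogen, a methoxy group, a trifluoromethyl group or an amine there. Going by these compounds, it also stays open whether the step from chloro to fluoro would be of similar size with a change made elsewhere on the shared core.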